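From 2-methoxyphenyl to 4-bromophenyl on the shared core

The compounds below may be only part of what the source reports. "The series", "measured", "known", "first", "only" and "open" are said of these compounds alone.

Of the compounds shown here, three with a shared core have been measured in a functional assay on MCF7 cells (Homo sapiens) for cytotoxicity, read by MTT assay, with a stated time of 72 h; on this read-out lower numbers stand for stronger inhibition and higher numbers for weaker inhibition. Compound 1 `COc1c(OCCCCN2CCN(C)CC2)cc(O)c2c(=O)cc(-c3ccc(C)cc3)oc12` gives 4020 nM, compound 2 `COc1c(OCCCCN2CCN(C)CC2)cc(O)c2c(=O)cc(-c3ccc(Cl)cc3)oc12` gives 3210 nM, and compound 3 `COc1ccccc1-c1cc(=O)c2c(O)cc(OCCCCN3CCN(C)CC3)c(OC)c2o1` gives 5430 nM. Compound 3 thus stands within the scatter of both others, and the three numbers cannot be put in a firm order.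

Compound 4 `COc1c(OCCCCN2CCN(C)CC2)cc(O)c2c(=O)cc(-c3ccc(Br)cc3)oc12` has not yet been measured. It carries 4-bromophenyl in place of 2-methoxyphenyl on an aromatic carbon, next to the ring oxygen (4-bromophenyl in place of 2-methoxyphenyl on an aromatic carbon).

Among the measured compounds shown here, no compound with a bromine has been measured, so the closest guide is compound 2, which carries 4-chlorophenyl at the same place. The step of a 1.7-fold higher number from compound 2 to compound 3 (0.23 log units; within the scatter) is the most relevant one, and it lies within the scatter. The step of a 1.4-fold higher number from compound 1 to compound 3 (0.13 log units; within the scatter) also stays within the scatter, as does a 1.3-fold lower number from compound 1 to compound 2 (0.10 log units; within the scatter). Changes at this place have so far moved the number very little, and compound 4 is therefore expected to lie close to compound 2 at 3210 nM. The expected change is a 1.6-fold lower number from compound 3 to compound 4 (0.22 log units; within the scatter), a small move toward a lower number that is not expected to exceed the scatter. For compound 4 the estimated value in this assay is 3300 nM, with an expected range from 1800 nM to 6000 nM.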

Compound 4, half-maximal inhibitory concentration: 3210 nM
Compound 4: the middle estimate sits 1.0-fold (0.01 log units) above what was measured; the range from low to high includes it.
By their numbers in this assay, from the lowest: compounds 2, 4, 1 and 3 (each within the scatter of the next).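

In this assay, bromo in place of chloro on the phenyl ring gives no change at the digits printed from compound 2 to compound 4 (within the scatter), and bromo in place of methyl gives a 1.3-fold lower number from compound 1 to compound 4 (0.10 log units; within the scatter), so exchanging this one substituent on the ring leaves the number inside the usual scatter for all three groups now compared at that spot. The larger exchange of the whole aryl group, 4-bromophenyl in place of 2-methoxyphenyl next to the ring oxygen, gives a 1.7-fold lower number from compound 3 to compound 4 (0.23 log units; within the scatter), which also stays within the scatter, so across these four compounds neither the kind of group on the phenyl ring nor the move from the 2-methoxyphenyl to a 4-substituted phenyl has separated one compound from another. Nothing available explains why the numbers stay so close together.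

The compounds shown carry only methyl, chloro, bromo and methoxy on this phenyl ring, so it remains open whether an amine, a carboxylic acid or a longer chain there would move the number beyond the scatter. From the compounds shown here alone, it also remains open whether an aryl group bearing two substituents, or a ring containing nitrogen in place of the phenyl, would do so.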